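The compounds below may be only part of what the source reports. "The series", "measured", "known", "first", "only" and "open" are said of these compounds alone.

Compound 1 `CCN1C(=O)C(O)(Cc2nnn[nH]2)c2ccccc21`: > 100000 nM
Compound 2 `Cc1ccc2c(c1)C(O)(Cc1nnn[nH]1)C(=O)N2C`: > 100000 nM

In a functional assay on BT-549 cells (Homo sapiens) for antiproliferative activity, read by MTT assay, with a stated time of 48 h (a higher number here means a weaker inhibitor, a lower number a stronger inhibitor), compound 1 gives > 100000 nM, which is a limit of the assay and not a number. In this assay compound 2 gives > 100000 nM, which is also a limit and not a number. Compound 2 therefore has no measured number that places it in the series, and the two results together stand at the limit of > 100000 nM in this assay, at which 2 of the 2 values shown sit.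

Compound 3 `CCN1C(=O)C(O)(Cc2nnn[nH]2)c2cc(C)ccc21` has yet to be measured. It departs from compound 2 at one point: methyl in place of hydrogen on a saturated chain carbon bound to an amide-type nitrogen in a ring. This is methyl in place of hydrogen on a saturated chain carbon bound to an amide-type nitrogen in a ring, so that methyl becomes ethyl. For the measured compounds named here, no measured pair shows the size of such a change. The expectation therefore rests on compound 2 and on (the limit of > 100000 nM in this assay, at which 2 of the 2 values shown sit). The estimated step that the limit leaves unreadable from compound 2 to compound 3 is expected to stay within the usual scatter, with neither direction favoured, and the assay will probably report only a limit again. For compound 3 the expected value is 120000 nM, with an estimated range from 50000 nM to 300000 nM.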

Compound 3, half-maximal inhibitory concentration: > 100000 nM
Compound 3 ended at the assay's limit; the forecaster's own chance of this, stated with the estimate: 85%; the middle value is on the limit's open side.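

In this assay compound 3 gives > 100000 nM and this is a limit of the assay, not a number. For the compounds shown here, no step to compound 3 from compound 1 or compound 2 can therefore be read. The compounds shown leave open whether either added methyl changes activity at all, and where any of them would stand as a number: the limit of > 100000 nM in this assay, at which 3 of the 3 values shown sit.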